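Compound 4: a chloro step at the limit

The compounds below may be only part of what the source reports. "The series", "measured", "known", "first", "only" and "open" are said of these compounds alone.

In a functional assay on HGC-27 cells (Homo sapiens) for cytotoxicity, read by MTT assay, with a stated time of 48 h (on this read-out higher numbers stand for weaker inhibition and lower numbers for stronger inhibition), compound 2 `COc1cc(OC)c(/C=C/C(=O)/C=C/c2cc3ccccc3nc2Oc2ccccc2)c(OC)c1` gives > 10000 nM as a limit and not a number. Compound 1 `COc1ccc(/C=C/C(=O)/C=C/c2cc3ccccc3nc2Oc2ccccc2)c(OC)c1` gives > 10000 nM as a limit too. Compound 3 `COc1ccc(OC)c(/C=C/C(=O)/C=C/c2cc3ccccc3nc2Oc2ccc(Br)cc2)c1` with bromo on its phenoxy group gives > 10000 nM as a limit as well. Going by the values given here, the only measured step is a step that the two limits leave unreadable from compound 1 to compound 2 and it offers no size to carry over. Among the compounds with values here, the whole picture is the limit of > 10000 nM in this assay, at which 3 of the 3 values shown sit, and no compound yet gives a number. Compound 4 `COc1cc(OC)c(/C=C/C(=O)/C=C/c2cc3ccccc3nc2Oc2cccc(Cl)c2)c(OC)c1` arises from compound 2 through chloro in place of hydrogen on an aromatic carbon as chloro in place of hydrogen on an aromatic carbon. No shift beyond the scatter in either direction is expected, so the estimated change is a step that the limit leaves unreadable from compound 2 to compound 4 for now. Compound 4 is expected at 15000 nM with an estimated range from 6000 nM to 40000 nM and will most likely read as a limit again.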

Compound 4, half-maximal inhibitory concentration: > 10000 nM
Compound 4: only a limit was reported; the forecaster's own chance of this, stated with the estimate: 75%; the middle value is on the limit's open side.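

Going by these compounds alone, compound 4, like compound 2, returns only a limit, so no step between compound 2 and compound 4 can be read. The compounds shown leave open whether chloro changes anything and whether any of them gives a number, with the whole set at one value: the limit of > 10000 nM in this assay, at which 4 of the 4 values shown sit.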